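The source may hold more compounds than are shown below. What is called first, only, known or untested is meant among the compounds shown, and "the series" means these compounds.

Working notes on the series in a functional assay on HeLa cells (Homo sapiens) for antiproliferative activity, read by sulforhodamine B assay, with a stated time of 48 h; on this read-out lower numbers stand for stronger inhibition of growth and higher numbers for weaker inhibition of growth. Compound 1 `O=C(NCc1cn(Cc2ccc(Cl)cc2)nn1)c1cn(-c2ccccc2)nc1-c1ccc(Cl)cc1` gives 470 nM in this assay. Compound 2 `COc1ccc(Cn2cc(CNC(=O)c3cn(-c4ccccc4)nc3-c3ccc(Cl)cc3)nn2)cc1` gives 1400 nM in this assay, and compound 3 `COc1cc(Cn2cc(CNC(=O)c3cn(-c4ccccc4)nc3-c3ccc(Cl)cc3)nn2)cc(OC)c1` gives 730 nM in this assay. On these numbers compound 3 sits between the other two: the step of a 1.6-fold higher number from compound 1 to compound 3 (0.19 log units; within the scatter) and the step of a 1.9-fold lower number from compound 2 to compound 3 (0.28 log units; within the scatter) both stay within the scatter, so compound 3 is not separated from either neighbour by a real difference.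

Compound 4 `COc1ccc(-c2nn(-c3ccccc3)cc2C(=O)NCc2cn(Cc3cc(OC)cc(OC)c3)nn2)cc1` has not been measured in this assay. It differs from compound 3 by methoxy in place of chloro on an aromatic carbon. Among the measured compounds shown here, the only measured step of the same kind is a 3.0-fold higher number from compound 1 to compound 2 (0.47 log units; beyond the scatter), in which the same exchange of chloro for methoxy was made on the ring carried by the saturated chain carbon bound to an aromatic nitrogen, not on the ring attached to the shared core. Nothing in the measured set tests the exchange at the position now concerned, so that step is only a loose guide. A modest rise of the number, in the direction of weaker inhibition, is the expectation, but a result within the scatter of compound 3 cannot be excluded.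

The expected step is a 2.1-fold higher number from compound 3 to compound 4 (0.31 log units; beyond the scatter). Compound 4 is therefore estimated at 1500 nM, with a range from 600 nM to 4000 nM.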

Compound 4, concentration for 50% growth inhibition: 12400 nM
The estimate for compound 4 lay 8.3-fold (0.92 log units) below the measured number; the whole stated range lies below it.
By their numbers in this assay, from the lowest: compounds 1, 3 and 2 (each within the scatter of the next, the first and the last beyond it); then compound 4.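

In this assay, the exchange of 4-chlorophenyl for 4-methoxyphenyl on the shared core gives a 17-fold higher number from compound 3 to compound 4 (1.23 log units; beyond the scatter), the first sign that this position responds strongly to a change of its substituent. Compound 3 and compound 4 differ only in this one group, so the chloro here cannot be exchanged for methoxy without a large loss of growth inhibition. The exchange also has no single size across the series, since the step on the ring carried by the saturated chain carbon does not predict the step here: the same change on two cores in this assay, a 3.0-fold higher number (0.47 log units; beyond the scatter) from compound 1 to compound 2 and a 17-fold higher number (1.23 log units; beyond the scatter) from compound 3 to compound 4, 5.7-fold (0.76 log units) apart, beyond the scatter of two such steps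

The compounds shown do not separate the effect of the position from that of its partner group, since compound 4 carries 3,5-dimethoxyphenyl at the other end of the molecule, and the size of the step with a 4-chlorophenyl group there remains unknown. Going by these compounds, it also remains open whether the large step is specific to methoxy, or whether a fluoro group, a hydroxy group or an amine at the same place on this ring would stay close to compound 3 or fall as far as compound 4.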